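This account rests on a few compounds, and the source may have more. Where it says the series, first, only, none or still open, it means among the compounds named here.

Three aryl-substituted members of the series have been run through an ADME assay on HEK293 cells (Homo sapiens) for cytotoxicity, read by MTT assay, with a stated time of 48 h; on this read-out higher numbers stand for weaker inhibition and lower numbers for stronger inhibition. Compound 1 `Cc1ccc(S(=O)(=O)/N=C(/CCNC2=CC(=O)c3ccccc3C2=O)Nc2ccccc2I)cc1` gives 49400 nM, compound 2 `Cc1ccc(S(=O)(=O)/N=C(/CCNC2=CC(=O)c3ccccc3C2=O)Nc2cccc(C)c2)cc1` gives 56200 nM, and compound 3 `Cc1ccc(S(=O)(=O)/N=C(/CCNC2=CC(=O)c3ccccc3C2=O)Nc2ccc(Cl)cc2Cl)cc1` gives 41900 nM. Compound 3 carries the lowest of the three numbers, but the step of a 1.2-fold lower number from compound 1 to compound 3 (0.07 log units; within the scatter) and the step of a 1.3-fold lower number from compound 2 to compound 3 (0.13 log units; within the scatter) both lie within the scatter, as does a 1.1-fold higher number from compound 1 to compound 2 (0.06 log units; within the scatter); the three aryl groups are not separated in this assay.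

Compound 4 `Cc1ccc(S(=O)(=O)/N=C(/CCNC2=CC(=O)c3ccccc3C2=O)NC(C)C)cc1` differs from compound 3 by isopropyl in place of 2,4-dichlorophenyl on an amine nitrogen. Going by the values given here, no measured step exchanges an aromatic group for an alkyl one, so the two aryl-to-aryl steps bearing on it only show that this position has so far tolerated variation without movement. The expectation for compound 4 is therefore no step beyond the scatter, a 1.1-fold higher number from compound 3 to compound 4 (0.06 log units; within the scatter), with a wide range to reflect the unexampled change: compound 4 is estimated at 48000 nM, between 16000 nM and 140000 nM.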

Compound 4, half-maximal inhibitory concentration: 71600 nM
Compound 4: middle estimate off by 1.5-fold (0.17 log units), on the low side, within the range that was stated.
By their numbers in this assay, from the lowest: compounds 3, 1, 2 and 4 (each within the scatter of the next).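

In this assay, the amine nitrogen now accepts an alkyl group as well as an aryl group without a step beyond the scatter: isopropyl gives a 1.7-fold higher number from compound 3 to compound 4 (0.23 log units; within the scatter) and a 1.3-fold higher number from compound 2 to compound 4 (0.11 log units; within the scatter) and a 1.4-fold higher number from compound 1 to compound 4 (0.16 log units; within the scatter) in turn. An aromatic ring at this place is therefore not required to keep the number within the scatter of the aryl compounds. No available data explain these steps.

Still open, as far as these compounds go, is whether a longer chain, a cyclohexyl group or a chain ending in an amine or a carboxylic acid would move the number beyond the scatter. The compounds shown also leave open any change away from this nitrogen, since the rest of the core stays the same.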